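Swapping nitro for amino in a stilbene-like sulfide series

The source may report more compounds than this note shows. Statements on the series, on what has been measured and on what is new or still open speak of the compounds shown alone.

Measured compounds:
Compound 1, `COc1cc(OC)c(/C=C/SCc2ccc(OC)c([N+](=O)[O-])c2)c(OC)c1`: 5000 nM
Compound 2, `COc1cc(OC)c(/C=C/[S+]([O-])Cc2ccc(OC)c([N+](=O)[O-])c2)c(OC)c1`: 15000 nM
Compound 3, `COc1cc(OC)c(/C=C/[S+]([O-])Cc2ccc(OC)c(N)c2)c(OC)c1`: 20 nM

Of the compounds shown here, three have been tested in a functional assay on K562 cells (Homo sapiens) for cytotoxicity, read by trypan blue exclusion, with a stated time of 96 h; a higher number here means a weaker inhibitor, a lower number a stronger inhibitor. In this assay compound 1 gives 5000 nM, while compound 2 gives 15000 nM and compound 3 gives 20 nM. The difference between the cores of compound 1 and compound 2 is not broken down here. Compound 3 arises from compound 2 by one change, (amino in place of nitro on an aromatic carbon), and that change made a large step: a 750-fold lower number from compound 2 to compound 3 (2.88 log units; beyond the scatter).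

Compound 4, `COc1cc(OC)c(/C=C/SCc2ccc(OC)c(N)c2)c(OC)c1`, has not yet been measured. It arises from compound 1 by the same change, (amino in place of nitro on an aromatic carbon). For the measured compounds named here, on a single example nothing can be said about how reliably this change repeats, yet the one example is strong. Because compound 1 gives 5000 nM, and because the same change from compound 2 to compound 3 made a 750-fold lower number from compound 2 to compound 3 (2.88 log units; beyond the scatter), a step of similar size is expected here, roughly a 500-fold lower number from compound 1 to compound 4 (2.70 log units; beyond the scatter). For compound 4 the expected value is therefore 10 nM, estimated to lie between 2 nM and 60 nM.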

Compound 4, half-maximal inhibitory concentration: 30 nM
Compound 4: the middle estimate sits 3.0-fold (0.48 log units) below what was measured, and the stated range covers the measured number.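

In this assay, amino in place of nitro on an aromatic carbon again made a large step on the second core, a 170-fold lower number from compound 1 to compound 4 (2.22 log units; beyond the scatter). Set side by side, the two examples point the same way but differ in size: the same change on two cores in this assay, a 750-fold lower number (2.88 log units; beyond the scatter) from compound 2 to compound 3 and a 170-fold lower number (2.22 log units; beyond the scatter) from compound 1 to compound 4, 4.5-fold (0.65 log units) apart, beyond the scatter of two such steps. The change therefore carried over between these two cores as a large drop in the number, but the size of the step on one core did not match the size on the other, and two cores cannot show how the change would behave on a third or why the two sizes differ.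

The compounds shown leave open whether another group in the same place, such as a hydroxyl, an acetamide or a dimethylamino group, would give a number as low as amino does. They also leave open whether the same swap would produce a large step on a core carrying a sulfone in the link between the two rings.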